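Replacing carboxy(difluoro)methyl in three closely matched compounds

The source may report more compounds than this note shows. Statements on the series, on what has been measured and on what is new or still open speak of the compounds shown alone.

In a functional assay on K562 cells (Homo sapiens) for cytotoxicity, read by trypan blue exclusion, with a stated time of 96 h (on this read-out lower numbers stand for stronger inhibition and higher numbers for weaker inhibition), compound 1 (`COC(=O)C(F)(F)Nc1cc(CS(=O)(=O)/C=C/c2c(OC)cc(OC)cc2OC)ccc1OC`) gives 250 nM, compound 2 (`COC(=O)C(Nc1cc(CS(=O)(=O)/C=C/c2c(OC)cc(OC)cc2OC)ccc1OC)c1ccc(Br)cc1`) gives 200 nM, and compound 3 (`COc1cc(OC)c(/C=C/S(=O)(=O)Cc2ccc(OC)c(NC(F)(F)C(=O)O)c2)c(OC)c1`) gives 150 nM. Compound 3 thus has the lowest number of the set, yet it cannot be separated from the others: a 1.7-fold lower number from compound 1 to compound 3 (0.22 log units; within the scatter), and a 1.3-fold lower number from compound 2 to compound 3 (0.12 log units; within the scatter). Compound 4 (`COc1cc(OC)c(/C=C/S(=O)(=O)Cc2ccc(OC)c(NC(C)(C)C(=O)O)c2)c(OC)c1`) differs from compound 3 by one exchange: 1-carboxy-1-methylethyl in place of carboxy(difluoro)methyl on a nitrogen on an aromatic ring. For the measured compounds named here, no measured step makes this exact exchange. The nearest evidence is the changes on the same nitrogen, a 1.3-fold lower number from compound 1 to compound 2 (0.10 log units; within the scatter), all small, so no shift beyond the scatter is expected. The expected change is a 1.3-fold higher number from compound 3 to compound 4 (0.12 log units; within the scatter). For compound 4 the estimated value is 200 nM, with an expected range of 70 nM to 600 nM.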

Compound 4, half-maximal inhibitory concentration: 7.5 nM
Beside the measured number, compound 4's estimate is 27-fold (1.43 log units) above it; measured number outside the range, below it.
By their numbers in this assay, from the lowest: compound 4; then compounds 3, 2 and 1 (each within the scatter of the next).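

At this nitrogen, the group matters far more than the three earlier compounds showed: they stayed within the scatter of one another in this assay, whereas 1-carboxy-1-methylethyl separates clearly from all of them, with a 20-fold lower number from compound 3 to compound 4 (1.30 log units; beyond the scatter), a 27-fold lower number from compound 2 to compound 4 (1.43 log units; beyond the scatter) and a 33-fold lower number from compound 1 to compound 4 (1.52 log units; beyond the scatter). The step from compound 3 is the most telling, since the carboxy group stays and only fluorine gives way to methyl.

As far as these compounds go, whether ethyl in place of methyl, or an amide in place of the carboxylic acid, would keep this low number remains open. Nothing available here explains the size of the step.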